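A few compounds are considered here, and "the series" means these few. Any claim that something is new, unique, unknown or untested is made for them only; others in the source may bear on it.

Measured compounds:
compound 1 `Cc1ccc(C2=NN(C(N)=S)C(c3ccc(Cl)cc3)C2)cc1` — in an assay on mitochondria for inhibition of Amine oxidase [flavin-containing] A (Bos taurus) (a lower number here means a stronger inhibitor, a higher number a weaker inhibitor), compound 1 gives 31 nM
compound 2 `Cc1ccc(C2=NN(C(N)=S)[C@H](c3ccc(Cl)cc3)C2)cc1` — compound 2 gives 50 nM
compound 3 `NC(=S)N1N=C(c2ccc(F)cc2)CC1c1ccc(Cl)cc1` — compound 3 gives 6 nM

Compound 3 has the lowest number of the three, and its gaps to compound 1 and to compound 2 are both beyond the scatter; the fluoro for methyl change gave a 5.2-fold lower number from compound 1 to compound 3 (0.71 log units; beyond the scatter).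

Compound 4 `NC(=S)N1N=C(c2ccc(F)cc2)C[C@H]1c1ccc(Cl)cc1` differs from compound 3 only in stereochemistry: the two compounds have the same atoms and bonds; at least one stereo element is drawn with a configuration in one of them and without one in the other: 1 of 1 stereo elements differ; a stereocentre at a saturated ring carbon is drawn without a configuration in compound 3 and S in compound 4. Among the compounds with values here, the one measured step of this kind is the pair compound 1 to compound 2, which rests on the fact that one of compounds 1 and 2 is drawn with a defined configuration and the other without, at the place where they differ and gave a 1.6-fold higher number from compound 1 to compound 2 (0.21 log units; within the scatter). On that evidence, drawing the single stereocentre as S on the core of compound 3 is expected to leave the number within the scatter, with at most a small drift toward a higher number, as seen from compound 1 to compound 2.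

Compound 4 is therefore estimated at 9 nM, with a range of 4 nM to 20 nM. The step expected is a 1.5-fold higher number from compound 3 to compound 4 (0.18 log units; within the scatter), not beyond the scatter.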

Compound 4, inhibition constant: 6 nM
Beside the measured number, compound 4's estimate is 1.5-fold (0.18 log units) above it, and the stated range covers the measured number.
By their numbers in this assay, from the lowest: compounds 3 and 4 (each within the scatter of the next); then compounds 1 and 2 (each within the scatter of the next).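

In this assay, drawing the saturated ring carbon as S on the fluoro core gives no change at the digits printed from compound 3 to compound 4 (within the scatter), and like a 1.6-fold higher number from compound 1 to compound 2 (0.21 log units; within the scatter) this lies within the scatter, so the stereo comparison now stands on two cores rather than one. Both comparisons set a defined drawing against an undefined one, and the newer one rests on this: the fact that one of compounds 3 and 4 is drawn with a defined configuration and the other without, at the place where they differ The fluoro in place of methyl change, until now seen only on the undefined pair, also appears on the S-drawn pair as an 8.3-fold lower number from compound 2 to compound 4 (0.92 log units; beyond the scatter), and the two steps agree: the same change on two cores in this assay, a 5.2-fold lower number (0.71 log units; beyond the scatter) from compound 1 to compound 3 and an 8.3-fold lower number (0.92 log units; beyond the scatter) from compound 2 to compound 4, 1.6-fold (0.21 log units) apart, within the scatter of two such steps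

On these data alone, how the R configuration at this ring carbon reads in this assay remains open. So does how a methoxy group or an amine on that aromatic carbon compares with fluoro and methyl.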